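Shortening the linker between the amide and the purine-bearing ring

A few compounds are considered here, and "the series" means these few. Any claim that something is new, unique, unknown or untested is made for them only; others in the source may bear on it.

Measured so far:
compound 1, `Nc1ccccc1NC(=O)/C=C/c1ccc(Cn2cnc3c(Nc4cccc(Cl)c4)nc(Cl)nc32)cc1`, 12.9%
compound 2, `Nc1ccccc1NC(=O)/C=C/c1ccc(Cn2cnc3c(NCc4ccccc4)nc(Cl)nc32)cc1`, 2.85%

Both compounds were tested in a functional assay on HCT-116 cells (Homo sapiens) for antiproliferative activity, read by CCK-8 assay, with a stated time of 72 h, tested at 2 uM; a lower number here means a weaker effect, a higher number a stronger effect of the compound at the concentration tested. Compound 1 gives 12.9% in this assay, and compound 2 gives 2.85%, the lowest of the two numbers. For the measured compounds named here, the only measured step, a number 10.1 percentage points lower from compound 1 to compound 2 (beyond the scatter), concerns the group on the ring nitrogen and says nothing about the part of the molecule that changes next.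

Compound 3, `Nc1ccccc1NC(=O)c1ccc(Cn2cnc3c(NCc4ccccc4)nc(Cl)nc32)cc1`, differs from compound 2 in one place: (2-aminophenyl)carbamoyl in place of 2-((2-aminophenyl)carbamoyl)ethenyl on an aromatic carbon. Going by the values given here, no measured pair varies this part of the structure, so there is no step to lean on, and the change touches neither of the groups that were varied before. With no guidance in the numbers, the expectation for the step of a number 1.2 percentage points higher from compound 2 to compound 3 (within the scatter) is that it stays within the usual scatter, in either direction. Compound 3 is therefore expected to give about 4% in this assay, with a range from -6% to 14%.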

Compound 3, a percentage reported as inhibition, at one concentration (the size of the read-out at that concentration, not a potency): 68.3%
Compound 3: the middle estimate sits 64.3 percentage points below what was measured, outside the stated range (above it).
By their numbers in this assay, from the lowest: compound 2; then compound 1; then compound 3.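

Going from the 2-((2-aminophenyl)carbamoyl)ethenyl group to (2-aminophenyl)carbamoyl on the same aromatic carbon gives a number 65.5 percentage points higher from compound 2 to compound 3 (beyond the scatter) in this assay, so this place on the ring, para to a large group, has a strong influence on the read-out. The earlier step changed the group on a nitrogen and was modest, whereas this one is large, even though the new group has only two fewer heavy atoms, one fewer double bond outside aromatic rings and the same counts of hydrogen-bond donors and acceptors. No measurement shown here explains why the shorter group gives so much more inhibition at the concentration tested.

These compounds cannot separate the effect of losing the double bond from the effect of shortening the group, and a saturated ethylene chain in the same place would tell the two apart. From the compounds shown here alone, it also remains open whether the gain carries over to the 3-chlorophenyl group of compound 1, and whether the 2-aminophenyl amide could be replaced by a hydroxamic acid or a carboxylic acid.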